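This account rests on a few compounds, and the source may have more. Where it says the series, first, only, none or still open, it means among the compounds named here.

Working notes on the series. In a functional assay on MDA-MB-231 cells (Homo sapiens) for antiproliferative activity, read by MTT assay, with a stated time of 72 h (on this read-out lower numbers stand for stronger inhibition and higher numbers for weaker inhibition), compound 1 (`COc1ccc(C(=O)O[C@H]2CC[C@]3(C)[C@H](CC[C@@](C)(O)[C@H]3CC[C@@H]3C(C)=CC[C@H]4[C@H](CC[C@]4(C)O)C3(C)C)OC2(C)C)cc1`) gives 30600 nM and compound 2 (`CC1=CC[C@H]2[C@H](CC[C@]2(C)O)C(C)(C)[C@@H]1CC[C@H]1[C@]2(C)CC[C@H](OC(=O)c3cccc(C(F)(F)F)c3)C(C)(C)O[C@H]2CC[C@@]1(C)O`) gives 36300 nM. These two values lie within the scatter of each other, so compound 2 stands level with compound 1. The next compound is compound 3 (`CC1=CC[C@H]2[C@H](CC[C@]2(C)O)C(C)(C)[C@@H]1CC[C@H]1[C@]2(C)CC[C@H](OC(=O)c3ccccc3Cl)C(C)(C)O[C@H]2CC[C@@]1(C)O`), and the change is 2-chlorophenyl in place of 3-(trifluoromethyl)phenyl on a carbonyl carbon, with 2-chlorophenyl in place of 3-(trifluoromethyl)phenyl on a carbonyl carbon. Going by the values given here, one measured step bears on this change: a 1.2-fold higher number from compound 1 to compound 2 (0.07 log units; within the scatter), also an exchange of the group on that carbonyl carbon. Since that step stays within the scatter, no step beyond the scatter is expected in this assay, and no direction can be assigned. Among the compounds with values here, this rests on a single step, and no measured compound carries 2-chlorophenyl. The expected change is a 1.1-fold lower number from compound 2 to compound 3 (0.05 log units; within the scatter). For compound 3 the estimated value is 32000 nM, with an expected range of 14000 nM to 70000 nM.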

Compound 3, half-maximal inhibitory concentration: 24300 nM
Compound 3: middle estimate off by 1.3-fold (0.12 log units), on the high side; the measured number falls inside the stated range.
By their numbers in this assay, from the lowest: compounds 3, 1 and 2 (each within the scatter of the next).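

In this assay the 2-chlorophenyl group on this carbonyl carbon gives no step beyond the scatter against either group tested so far, whether it replaces 3-(trifluoromethyl)phenyl (a 1.5-fold lower number from compound 2 to compound 3 (0.17 log units; within the scatter)) or 4-methoxyphenyl (a 1.3-fold lower number from compound 1 to compound 3 (0.10 log units; within the scatter)). Going by these compounds alone, three differently substituted phenyl groups now stand level at this position, where the earlier pair offered only one comparison. Nothing available explains this flat reading.

Still open, going by these compounds, is whether a group of another kind on this carbonyl carbon, such as a longer alkyl chain or a phenyl ring carrying an amine or a carboxylic acid, would give a step beyond the scatter. Also open, on these data alone, is whether an amide linkage in place of the ester would move the number in this assay.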